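Sulfone in Place of Acid on a Leukotriene Ligand

The source may report more compounds than this note shows. Statements on the series, on what has been measured and on what is new or still open speak of the compounds shown alone.

Of the compounds shown here, three built on a shared core have been measured. Compound 1 `CC(=O)c1ccc(OCCCCC#N)cc1O` carries a short chain ending in a nitrile; in an assay on isolated protein for binding affinity to leukotriene B4 receptor 1 (Homo sapiens), tested at 1 uM (on this read-out lower numbers stand for less inhibition and higher numbers for more inhibition at the one concentration tested (going by the name of the read-out)), compound 1 gives 0%. Compound 2 `C=CCc1cc(C(C)=O)c(O)cc1OCCCCCCCCCCC#N` has a longer nitrile-ended chain together with an allyl group on the core, and in this assay compound 2 gives 14%. Compound 3 `CCc1cc(C(C)=O)c(O)cc1OCCCCCC(C)(C)C(=O)O` ends its chain in a carboxylic acid; in this assay compound 3 gives 73%, the highest of the three numbers, standing beyond the scatter above both compound 2 and compound 1.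

Compound 4 `CCc1cc(C(C)=O)c(O)cc1OCCCCCCS(C)(=O)=O` differs from compound 3 in one place: (methylsulfonyl)methyl in place of 1-carboxy-1-methylethyl on a saturated chain carbon, five bonds along the chain from an oxygen on an aromatic ring. Within the data shown here, no measured pair in this set isolates such a change, so the step has to be estimated. The only hydrogen-bond donor of the chain end is removed, and the two compounds without an acid end, compound 1 and compound 2, sit far below compound 3. On that basis the step from compound 3 to compound 4 in this assay is expected to be a drop beyond the scatter, a number 43 percentage points lower from compound 3 to compound 4 (beyond the scatter). Compound 4 is accordingly estimated at 30% in this assay, with a range from 8% to 60%.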

Compound 4, a percentage reported as inhibition, at one concentration (the size of the read-out at that concentration, not a potency): 62%
Compound 4: the middle estimate sits 32 percentage points below what was measured, and the stated range ends below it.
By their numbers in this assay, from the lowest: compound 1; then compound 2; then compound 4; then compound 3.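

The change from 1-carboxy-1-methylethyl to (methylsulfonyl)methyl, on a saturated chain carbon, five bonds along the chain from an oxygen on an aromatic ring, gives in this assay a step of a number 11 percentage points lower from compound 3 to compound 4 (beyond the scatter), so it has a real but limited cost. This pair shows that a carboxylic acid end is not required at this position for a high reading, since compound 4 , whose chain end has 0 hydrogen-bond donors, still gives 62% in this assay. Nothing available explains the size of this step.

The step replaces the whole chain end at once, so the compounds shown cannot separate the loss of the carboxylic acid from the loss of the two methyl groups on the carbon that carries it, or from the sulfone itself. Still open, from the compounds shown here alone, is how a sulfonamide, a tetrazole or a plain carboxylic acid without those methyl groups would read at this position, and whether compound 3 and compound 4 would stay this close in a full potency measurement rather than at the one concentration tested.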